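The source may report more compounds than this note shows. Statements on the series, on what has been measured and on what is new or still open speak of the compounds shown alone.

Measured compounds:
- compound 1, `COc1cc(C(=O)O)ccc1Cc1cn(C(c2ccccc2)c2ccccc2)c2ccc([N+](=O)[O-])cc12`: 1800 nM
- compound 2, `COc1cc(C(=O)O)ccc1Cc1cn(C(c2ccccc2)c2ccccc2)c2ccc(Cl)cc12`: 1800 nM

In a functional assay for inhibition, with Homo sapiens as the target (a lower number here means a stronger inhibitor, a higher number a weaker inhibitor), compound 2 gives 1800 nM, level with compound 1 within the scatter; the step of no change at the digits printed from compound 1 to compound 2 (within the scatter) shows no change. Compound 3, `COc1cc(C(=O)O)ccc1Cc1cn(C(c2ccccc2)c2ccccc2)c2ccc(Br)cc12`, differs from compound 2 by bromo in place of chloro on an aromatic carbon. For the measured compounds named here, the only measured step at this position, nitro to chloro, moved nothing beyond the scatter, so exchanging one halogen for another there is expected to give no step beyond the scatter in this assay, no change at the digits printed from compound 2 to compound 3 (within the scatter). Compound 3 is therefore estimated at 1800 nM, with a range from 900 nM to 3600 nM.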

Compound 3, half-maximal inhibitory concentration: 1200 nM
Estimate against measurement, compound 3: 1.5-fold (0.18 log units) above, within the range that was stated.
By their numbers in this assay, from the lowest: compounds 3, 1 and 2 (each within the scatter of the next).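

In this assay the swap of one halogen for another gives a 1.5-fold lower number from compound 2 to compound 3 (0.18 log units; within the scatter) and the swap of nitro for bromo gives a 1.5-fold lower number from compound 1 to compound 3 (0.18 log units; within the scatter) as its second reading at this position. Chloro, bromo and nitro on this aromatic carbon thus stand within the scatter of one another, so the position now shows the same flat result for three groups rather than two. (Nothing on hand gives a reason for this result). From the compounds shown here alone, whether an amine, a carboxylic acid or a plain hydrogen on this carbon would stay level with these three remains open.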